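Methoxy for bromo on the pendant phenyl of compound 2

A few compounds are considered here, and "the series" means these few. Any claim that something is new, unique, unknown or untested is made for them only; others in the source may bear on it.

Two compounds sharing a core carry a measurement in a functional assay on HT-29 cells (Homo sapiens) for antiproliferative activity, read by MTT assay, with a stated time of 72 h; a higher number here means a weaker inhibitor, a lower number a stronger inhibitor. Compound 1 `COc1ccc(-n2c(=O)c(C(=O)Nc3ccc(Oc4ccnc5[nH]ccc45)cc3)cc3cccnc32)cc1` gives 1260 nM in this assay. Compound 2 `Cn1ccc2c(Oc3ccc(NC(=O)c4cc5cccnc5n(-c5ccc(Br)cc5)c4=O)cc3)ccnc21` gives 690 nM in this assay, the lowest of the two numbers, with compound 1 standing within the scatter of it. Compound 1 and compound 2 differ in more than one place, so their two values alone cannot be tied to either change. The step from compound 2 leads to compound 3 `COc1ccc(-n2c(=O)c(C(=O)Nc3ccc(Oc4ccnc5c4ccn5C)cc3)cc3cccnc32)cc1`, where the change is methoxy in place of bromo on an aromatic carbon. Among the measured compounds shown here, no measured pair of compounds shows this change alone. Compound 1, which also carries methoxy at this place though with another difference elsewhere, shows a number within the scatter of that of compound 2, so the exchange is expected to leave the value of compound 3 close to that of compound 2 in this assay, with a step of a 1.3-fold higher number from compound 2 to compound 3 (0.12 log units; within the scatter) that is not expected to exceed the scatter. Compound 3 is therefore estimated at 900 nM in this assay, within a range from 400 nM to 2000 nM.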

Compound 3, half-maximal inhibitory concentration: 2050 nM
Estimate against measurement, compound 3: 2.3-fold (0.36 log units) below; measured number outside the range, above it.
By their numbers in this assay, from the lowest: compounds 2, 1 and 3 (each within the scatter of the next, the first and the last beyond it).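

In this assay, the change from 4-bromophenyl to 4-methoxyphenyl now stands alone, and it gives a 3.0-fold higher number from compound 2 to compound 3 (0.47 log units; beyond the scatter) as a modest step beyond the scatter, so this place on the aromatic ring does register the exchange, something compound 1 could not show while it differed from compound 2 in more than one place. The methoxy pair adds a second single change, methyl in place of hydrogen on an aromatic nitrogen, which gives a 1.6-fold higher number from compound 1 to compound 3 (0.21 log units; within the scatter) and stays within the scatter, so this pair does not resolve any effect of that methyl group. Nothing available here accounts for the step from bromo to methoxy.

The compounds shown leave open how an amine or a nitrile would read at this place, since only bromo and methoxy stand there. They also leave open whether the step from bromo to methoxy would keep its size with hydrogen rather than methyl on the aromatic nitrogen.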